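Extending the oxygen substituent of compound 3

The source may report more compounds than this note shows. Statements on the series, on what has been measured and on what is new or still open speak of the compounds shown alone.

In a functional assay on a cell-free system (plasma, Oryctolagus cuniculus) for inhibition, with stated times of 5 min, 1 min and 6 min (a higher number here means a weaker inhibitor, a lower number a stronger inhibitor), compound 1 (`CCOC(=O)c1c(C)nc(-c2cccc(C#N)c2)n1OC`) gives 9130 nM, compound 2 (`CCOC(=O)c1c(C)nc(-c2cccc(C#N)c2)n1OCc1ccc(C#N)cc1`) gives 4240 nM and compound 3 (`COn1c(-c2cccc(C#N)c2)nc(C)c1C(=O)O`) gives 7990 nM. Compound 3 lies within the scatter of both compound 1 and compound 2, although those two differ by more than the scatter.

Compound 4 (`Cc1ccc(COn2c(-c3cccc(C#N)c3)nc(C)c2C(=O)O)cc1`) keeps the carboxylic acid of compound 3 and has 4-methylphenyl in place of hydrogen on a saturated chain carbon bound to an oxygen on an aromatic ring, which reads as methyl to 4-methylbenzyl: 4-methylphenyl in place of hydrogen on a saturated chain carbon bound to an oxygen on an aromatic ring.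

Among the compounds with values here, two measured steps bear on this change. The closest is a 2.2-fold lower number from compound 1 to compound 2 (0.33 log units; beyond the scatter), modest but beyond the scatter, where 4-cyanophenyl enters at the same place on the ethyl ester. The other is a 1.1-fold lower number from compound 1 to compound 3 (0.06 log units; within the scatter), within the scatter, which links the ester to the acid. Within the data shown here, no measured pair shows whether the ester step carries over to the acid, and 4-methylphenyl itself is untested. A modest move to a lower number in this assay is therefore expected, estimated as a 2.2-fold lower number from compound 3 to compound 4 (0.35 log units; beyond the scatter). The estimate for compound 4 is 3600 nM, with an expected range of 700 nM to 9000 nM.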

Compound 4, half-maximal inhibitory concentration: 6560 nM
Compound 4: the middle estimate sits 1.8-fold (0.26 log units) below what was measured; measured number inside the range.
By their numbers in this assay, from the lowest: compounds 2, 4, 3 and 1 (each within the scatter of the next, the first and the last beyond it).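

On the acid, this position accepts 4-methylphenyl, with its 7 heavy atoms, on a saturated chain carbon bound to an oxygen on an aromatic ring, with a 1.2-fold lower number from compound 3 to compound 4 (0.09 log units; within the scatter) in this assay. Within the data shown here, the step beyond the scatter seen on the ethyl ester, a 2.2-fold lower number from compound 1 to compound 2 (0.33 log units; beyond the scatter), therefore has no counterpart in this acid pair, although the two steps differ both in the entering group and in the ester or acid that carries it, and the compounds cannot separate these two differences. Nothing available on these compounds accounts for this result.

From the compounds shown here alone, whether 4-cyanophenyl on the acid would repeat the ester step, and whether 4-methylphenyl on the ethyl ester would match the acid step, remain open. Also open, going by these compounds, is how an amine or a longer chain in place of 4-methylphenyl, at this same place on the acid, would read in this assay.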